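Methyl on a Nitrogen: Two Steps in Lipophilicity

The source may report more compounds than this note shows. Statements on the series, on what has been measured and on what is new or still open speak of the compounds shown alone.

Compound 1, `COc1nn(CC(N)=O)c2ncnc(NS(=O)(=O)c3cccc(Cl)c3Cl)c12`: in a physicochemical assay for lipophilicity (on this read-out higher numbers stand for higher lipophilicity and lower numbers for lower lipophilicity), compound 1 gives 1.1.
Compound 2, `CNC(=O)Cn1nc(OC)c2c(NS(=O)(=O)c3cccc(Cl)c3Cl)ncnc21`: in this assay compound 2 gives 1.3.
Compound 3, `COc1nn(C)c2nc(N)nc(NS(=O)(=O)c3cccc(Cl)c3Cl)c12`: in this assay compound 3 gives 2.4.

Compound 1 and compound 2 differ in one place, (methyl in place of hydrogen on an amide-type nitrogen). This change made a step of a number 0.20 log units higher from compound 1 to compound 2 (within the scatter). Compound 3 stands highest of the three measured numbers; its values lie beyond the scatter both from compound 2 and from compound 1. The difference between the core of compound 3 and the core of compound 1 is not broken down here.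

Compound 4, `CNc1nc(NS(=O)(=O)c2cccc(Cl)c2Cl)c2c(OC)nn(C)c2n1`, has not yet been measured in this assay. It differs from compound 3 by methyl in place of hydrogen on a nitrogen on an aromatic ring. The surroundings of the place are not the same as before: in the earlier pair the methyl enters on an amide-type nitrogen whose other neighbour is a carbonyl carbon, whereas here it enters on a nitrogen on an aromatic ring whose other neighbour is an aromatic carbon. So this is the same kind of change, not the same change. Within the data shown here, for compound 4 the step is expected to be a number 0.40 log units higher from compound 3 to compound 4 (beyond the scatter), somewhat larger than the step of a number 0.20 log units higher from compound 1 to compound 2 (within the scatter), since only that one earlier step is available as a guide and the place differs. Starting from the value of compound 3, 2.4, compound 4 is estimated at 2.8, with a likely range from 2.4 to 3.2.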

Compound 4, distribution coefficient: 3.2
For compound 4 the middle estimate is 0.40 log units below the measured one; the measured number falls inside the stated range.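

In this assay, methyl in place of hydrogen on a nitrogen on an aromatic ring gives a step of a number 0.80 log units higher from compound 3 to compound 4 (beyond the scatter), while methyl in place of hydrogen on an amide-type nitrogen gave a step of a number 0.20 log units higher from compound 1 to compound 2 (within the scatter). So this kind of change did not carry over as a fixed increment: a step that stayed within the scatter on one core lies beyond it on the other, but with only these two pairs, and with the nitrogen differing along with the core, the data cannot say whether the core, the kind of nitrogen or both set the size of the step. No measurement shown here explains the difference between the two steps.

The compounds shown leave open how a longer chain such as ethyl or propyl in place of the methyl on that nitrogen, or a dimethylamino group in place of the methylamino group, would read in this assay. Also open, going by these compounds, is what the same methyl change would do on the same kind of nitrogen on a different core, the comparison that could separate the effect of the core from that of the place.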